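The source may report more compounds than this note shows. Statements on the series, on what has been measured and on what is new or still open speak of the compounds shown alone.

Of the compounds shown here, three sharing one core have been measured in an in vitro ADME assay on microsomes from liver (Homo sapiens) for pharmacokinetics, read by LC-MS, with a stated time of 10 min, tested at 1 uM; a higher number here means faster removal of the compound, a lower number slower removal. Compound 1 `COc1ccc(NC(=O)[C@H]2CN(C)C[C@@H]2c2ccc(/C=C/C(=O)Nc3ccccc3N)cc2)cc1` gives 14 mL/min/kg, compound 2 `CC(C)c1ccc(NC(=O)[C@H]2CN(C)C[C@@H]2c2ccc(/C=C/C(=O)Nc3ccccc3N)cc2)cc1` gives 10 mL/min/kg, and compound 3 `CN1C[C@H](C(=O)Nc2ccccc2F)[C@@H](c2ccc(/C=C/C(=O)Nc3ccccc3N)cc2)C1` gives 10 mL/min/kg. Compound 3 is thus level with compound 2 at the digits shown, and all three numbers lie within the usual scatter of one another.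

The next compound, compound 4 `CN1C[C@H](C(=O)Nc2ccc(Cl)cc2F)[C@@H](c2ccc(/C=C/C(=O)Nc3ccccc3N)cc2)C1`, differs from compound 3 at a single place: chloro in place of hydrogen on an aromatic carbon. In words, this is chloro in place of hydrogen on an aromatic carbon, meta to a fluoro group and para to a large group, so that 2-fluorophenyl becomes 4-chloro-2-fluorophenyl.

The closest evidence comes from changes on this same aromatic group. Isopropyl in place of methoxy gave a 1.4-fold lower number from compound 1 to compound 2 (0.15 log units; within the scatter). Putting 2-fluorophenyl in place of 4-methoxyphenyl gave a 1.4-fold lower number from compound 1 to compound 3 (0.15 log units; within the scatter), and putting it in place of 4-isopropylphenyl gave no change at the digits printed from compound 2 to compound 3 (within the scatter). For the measured compounds named here, all three steps stay within the scatter, although none of them adds a chloro group, so the data hold no direct precedent.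

No step beyond the scatter is therefore expected in either direction, and the estimated step is no change at the digits printed from compound 3 to compound 4 (within the scatter). Compound 4 is expected at 10 mL/min/kg, with an estimated range of 6 mL/min/kg to 17 mL/min/kg.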

Compound 4, clearance: 11 mL/min/kg
Compound 4: middle estimate off by 1.1-fold (0.04 log units), on the low side; the measured number falls inside the stated range.
By their numbers in this assay, from the lowest: compounds 2, 3, 4 and 1 (each within the scatter of the next).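

In this assay, for the compounds shown here, chloro in place of hydrogen on the 2-fluorophenyl group, at the aromatic carbon para to a large group and meta to the fluoro group, gives a 1.1-fold higher number from compound 3 to compound 4 (0.04 log units; within the scatter) and is the first direct reading of adding a chlorine atom to this aromatic group. The new 4-chloro-2-fluorophenyl group also sits within the scatter of the two groups carrying a single substituent, with a 1.1-fold higher number from compound 2 to compound 4 (0.04 log units; within the scatter) against 4-isopropylphenyl and a 1.3-fold lower number from compound 1 to compound 4 (0.10 log units; within the scatter) against 4-methoxyphenyl, so all four aromatic groups shown on this amide nitrogen remain indistinguishable in this read-out. No measurement on hand explains why these numbers lie so close together.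

The aromatic groups shown carry only chloro, fluoro, methoxy and isopropyl, so it remains open whether an amine, a carboxylic acid or a longer chain at the same carbon would stay within the scatter in this assay as well. The chloro step has also been read only with the fluoro group present, which leaves open what a 4-chlorophenyl group would give.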